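Pyridin-4-yl replacing the fluoropyridinyl ether in the dione series

The source may hold more compounds than are shown below. What is called first, only, known or untested is meant among the compounds shown, and "the series" means these compounds.

Working notes on two measured compounds and one open position. Compound 1 `O=C1C(=O)N(Cc2ccc(Oc3ccccn3)cc2)c2ccc(OC(F)(F)F)cc21` and compound 2 `O=C1C(=O)N(Cc2ccc(Oc3cccc(F)n3)cc2)c2ccc(OC(F)(F)F)cc21` share the same core and differ only in fluoro in place of hydrogen on an aromatic carbon. In a functional assay on CHO cells for positive allosteric modulation of muscarinic acetylcholine receptor M5 (Homo sapiens), read by FLIPR and calcium flux, with a stated time of 1 h (a lower number here means a smaller maximal response, a higher number a larger maximal response), compound 1 gives 46%, and in this assay compound 2 gives 62%. Within the data shown here, the step of a number 16 percentage points higher from compound 1 to compound 2 (beyond the scatter) is the only measured step in the set. Compound 2 therefore stands highest of the two numbers, with compound 1 the nearest and lower by that step.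

Compound 3 `O=C1C(=O)N(Cc2ccc(-c3ccncc3)cc2)c2ccc(OC(F)(F)F)cc21` is not yet measured. It differs from compound 2 by pyridin-4-yl in place of (6-fluoropyridin-2-yl)oxy on an aromatic carbon. The measured step from compound 1 to compound 2 touches only the fluoro on the (6-fluoropyridin-2-yl)oxy group, which here leaves entirely; nothing measured speaks to pyridin-4-yl bound directly to the ring. Among the measured compounds shown here, the one known step was modest and points to the fluoro as a contributor, so its loss is expected to cost part of that gain, while the rest of the change is unreadable from the data. The expected step is a number 17 percentage points lower from compound 2 to compound 3 (beyond the scatter). For compound 3 in this assay the estimate is 45%, with a range from 25% to 70%.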

Compound 3, largest response reached (Emax), in percent of the reference or control that the assay uses: 60%
Estimate against measurement, compound 3: 15 percentage points below; low and high end bracket the measured number.
By their numbers in this assay, from the lowest: compound 1; then compounds 3 and 2 (each within the scatter of the next).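

In this assay, replacing the whole (6-fluoropyridin-2-yl)oxy group with pyridin-4-yl on the aromatic carbon gives a number 2 percentage points lower from compound 2 to compound 3 (within the scatter), so at this position, para to a large group, the maximal response holds with neither the ether oxygen nor the fluoro present. Among these compounds, replacing the unfluorinated (pyridin-2-yl)oxy group with pyridin-4-yl gives a number 14 percentage points higher from compound 1 to compound 3 (beyond the scatter), which shows that a fluoro is not the only change at this position that lifts the maximal response over that of compound 1. The series offers no independent measurement that would explain either step, so these notes record the numbers without an account of their origin.

From the compounds shown here alone, because the linker and the attachment point of the pyridine nitrogen change together in these steps, their separate contributions remain open, and a (pyridin-4-yl)oxy group or a directly bound pyridin-2-yl would be needed to tell them apart. Also open, going by these compounds, is whether a fluoro on the pyridin-4-yl ring would raise the maximal response, and whether a phenyl ring or an amine at this position would hold it.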